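Moving one methoxy group: what to expect for compound 4

The compounds below may be only part of what the source reports. "The series", "measured", "known", "first", "only" and "open" are said of these compounds alone.

Measured in an ADME assay on HepG2 2.2.15 cells (Homo sapiens) for cytotoxicity, read by CCK-8 assay, with a stated time of 8 days; on this read-out higher numbers stand for lower toxicity in this test and lower numbers for higher toxicity in this test:
- Compound 1 `CCOc1ccc(-n2cc(C(=O)c3ccc(OC)cc3O)ccc2=O)cc1`: > 100000 nM, a limit of the assay
- Compound 2 `COc1ccc(-c2cc(NC(=O)c3ccccc3O)c[nH]c2=O)cc1`: > 100000 nM, a limit of the assay
- Compound 3 `COc1ccc(-c2cc(NC(=O)c3ccc(OC)cc3O)c[nH]c2=O)cc1`: 49900 nM

For the measured compounds named here, compound 3 is the only compound with an actual number, 49900 nM. The other two results are limits: the limit of > 100000 nM in this assay, at which 2 of the 3 values shown sit.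

Compound 4 `COc1ccc(-c2cc(NC(=O)c3cccc(OC)c3O)c[nH]c2=O)cc1` has the same atoms as compound 3, joined differently: 2-hydroxy-3-methoxyphenyl in place of 2-hydroxy-4-methoxyphenyl on a carbonyl carbon. Going by the values given here, the one measured step that bears on this change is an at least 2.0-fold lower number from compound 2 to compound 3 (0.30 log units; that floor lies within the scatter), for methoxy in place of hydrogen on an aromatic carbon. That step only gives a floor, and the floor lies within the scatter. No step beyond the scatter is therefore expected in either direction in this assay. The expected step is a 1.3-fold higher number from compound 3 to compound 4 (0.11 log units; within the scatter). For compound 4 the estimated value is 65000 nM, with an expected range from 30000 nM to 130000 nM.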

Compound 4, half-maximal cytotoxic concentration: 49200 nM
The estimate for compound 4 lay 1.3-fold (0.12 log units) above the measured number; the range from low to high includes it.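

In this assay, moving the methoxy group, so that 2-hydroxy-3-methoxyphenyl replaces 2-hydroxy-4-methoxyphenyl on the carbonyl carbon, gives a 1.0-fold lower number from compound 3 to compound 4 (0.01 log units; within the scatter), so the two placements cannot be told apart in this test. Adding methoxy in the new placement gives an at least 2.0-fold lower number from compound 2 to compound 4 (0.30 log units; that floor lies within the scatter), which is only a floor, because the starting value is a limit of the assay: the limit of > 100000 nM in this assay, at which 2 of the 4 values shown sit.

From the compounds shown here alone, it remains open whether an amine or a carboxylic acid in place of this methoxy group would shift the number beyond the usual scatter.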